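Swapping the Aryl Group on a Carbamate: Compound 4

The source may report more compounds than this note shows. Statements on the series, on what has been measured and on what is new or still open speak of the compounds shown alone.

Three compounds share one core and differ in the aryl group on an amide-type nitrogen and in a side chain. In a functional assay on PANC-1 cells (Homo sapiens) for inhibition, read by MTT assay, with a stated time of 24 h, tested at 10 uM (on this read-out lower numbers stand for less inhibition and higher numbers for more inhibition at the one concentration tested (going by the name of the read-out)), compound 1 `CC(C)=CCC1Cc2c(OC(=O)Nc3cccc(C(F)(F)F)c3)cc(=O)n(CCCO)c2CC1(C)C` gives 54.3%, compound 2 `COc1ccc(NC(=O)Oc2cc(=O)n(CCCO)c3c2CC(C/C=C(\C)CCC=C(C)C)C(C)(C)C3)cc1` gives 64.1%, and compound 3 `CC(C)=CCC/C(C)=C/CC1Cc2c(OC(=O)Nc3ccccc3F)cc(=O)n(CCCO)c2CC1(C)C` gives 71.6%. Compound 3 holds the highest of the three numbers, but its gap to compound 2 lies within the usual scatter, so those two cannot be ranked; only compound 1 stands clearly lower. Going by the values given here, the single one-place step measured, a number 7.5 percentage points higher from compound 2 to compound 3 (within the scatter), exchanged the aryl group and stayed within the scatter.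

Compound 4 `CC(C)=CCC/C(C)=C/CC1Cc2c(OC(=O)Nc3cccc(C(F)(F)F)c3)cc(=O)n(CCCO)c2CC1(C)C` comes from compound 3 by 3-(trifluoromethyl)phenyl in place of 2-fluorophenyl on an amide-type nitrogen. Compound 1 also carries this group, though the rest of compound 1 is not the same, and compound 1 gives 54.3%. Among the compounds with values here, the one measured aryl swap, a number 7.5 percentage points higher from compound 2 to compound 3 (within the scatter), moved little, so no step beyond the scatter is expected here. Compound 4 is expected to show a number 7.6 percentage points lower from compound 3 to compound 4 (within the scatter). For compound 4 the estimate is 64%, between 50% and 78%.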

Compound 4, a percentage reported as inhibition, at one concentration (the size of the read-out at that concentration, not a potency): 44%
Beside the measured number, compound 4's estimate is 20 percentage points above it; measured number below the stated range.
By their numbers in this assay, from the lowest: compound 4; then compounds 1, 2 and 3 (each within the scatter of the next, the first and the last beyond it).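

In this assay, going by these compounds alone, the aryl group on the amide-type nitrogen can move the number beyond the scatter: 3-(trifluoromethyl)phenyl in place of 2-fluorophenyl gives a number 27.6 percentage points lower from compound 3 to compound 4 (beyond the scatter) and in place of 4-methoxyphenyl gives a number 20.1 percentage points lower from compound 2 to compound 4 (beyond the scatter) while the one earlier aryl swap stayed within the scatter. The side chain matters too: with 3-(trifluoromethyl)phenyl on both compounds, 3-methylbut-2-en-1-yl in place of hydrogen on a saturated chain carbon bound to a double-bonded chain carbon gives a number 10.3 percentage points lower from compound 1 to compound 4 (beyond the scatter) and so the longer chain goes with the lower number here. Nothing available explains why these changes lower the number.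

As far as these compounds go, whether the same drops would appear with other aryl groups stays open. A phenyl carrying an amine or a carboxylic acid on the same nitrogen would test how far this trend extends.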